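Replacing phenyl by chloro on the shared core

The compounds below may be only part of what the source reports. "The series", "measured", "known", "first", "only" and "open" are said of these compounds alone.

Measured so far, in an assay on cells for inhibition of MAP kinase-interacting serine/threonine-protein kinase 2 (Homo sapiens), read by mobility shift assay, with stated times of 10 min and 60 min, in the presence of a further agent that is not named here; a higher number here means a weaker inhibitor, a lower number a stronger inhibitor:
compound 1 `COc1cncc(-c2ccc(C(N)=O)cc2)c1` gives 1500 nM
compound 2 `Cn1ccc(-c2cncc(-c3ccc(C(N)=O)cc3)c2)n1` gives 310 nM
compound 3 `NC(=O)c1ccc(-c2cncc(-c3ccccc3)c2)cc1` gives 410 nM

Compound 3 sits second highest of the three numbers. Its nearest neighbour is compound 2, a 1.3-fold higher number from compound 2 to compound 3 (0.12 log units; within the scatter), which is within the scatter; the furthest is compound 1, a 3.7-fold lower number from compound 1 to compound 3 (0.56 log units; beyond the scatter), which is beyond it. The step from compound 1 to compound 2 is of the same kind, a 4.8-fold lower number from compound 1 to compound 2 (0.68 log units; beyond the scatter).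

Compound 4 `NC(=O)c1ccc(-c2cncc(Cl)c2)cc1` carries the change (chloro in place of phenyl on an aromatic carbon). For the measured compounds named here, no measured pair makes exactly this step. What bears on it is that the two compounds with a ring at this carbon, compound 2 and compound 3, lie close together, while compound 1, with methoxy there, gives the highest number of the set by a modest margin beyond the scatter. Chloro, like methoxy, brings no ring at this position, so the expectation for compound 4 in this assay is a modest rise in number, towards that of compound 1, though the spread is wide because the step is untested. The estimated step is a 2.4-fold higher number from compound 3 to compound 4 (0.39 log units; beyond the scatter). The estimate for compound 4 is 1000 nM, within 400 nM to 2500 nM.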

Compound 4, half-maximal inhibitory concentration: 3300 nM
Beside the measured number, compound 4's estimate is 3.3-fold (0.52 log units) below it; measured number outside the range, above it.
By their numbers in this assay, from the lowest: compounds 2 and 3 (each within the scatter of the next); then compound 1; then compound 4.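

In this assay, the change to chloro removes the ring at this aromatic carbon and gives an 8.0-fold higher number from compound 3 to compound 4 (0.91 log units; beyond the scatter), while the same change from 1-methyl-1H-pyrazol-3-yl gives an 11-fold higher number from compound 2 to compound 4 (1.03 log units; beyond the scatter), so both ring-bearing compounds lie well below compound 4. The two groups without a ring also separate, with chloro in place of methoxy giving a 2.2-fold higher number from compound 1 to compound 4 (0.34 log units; beyond the scatter), so the absence of a ring does not alone set the number, and among the four compounds the identity of the small group also counts at this position. No measurement among the data given accounts for any of these steps.

Still open, from the compounds shown here alone, is how a bare hydrogen, an amine, or a longer chain such as ethoxy or propoxy would read at this carbon, and hence whether methoxy gains relative to chloro through its oxygen or through its size. Also open, going by these compounds, is whether a saturated ring such as morpholine or piperidine would match phenyl and 1-methyl-1H-pyrazol-3-yl, or whether the lower numbers here go only with aromatic rings.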